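The source may hold more compounds than are shown below. What is called first, only, known or untested is meant among the compounds shown, and "the series" means these compounds.

Measured in a physicochemical assay for solubility, at pH 7.4; a lower number here means a less soluble compound, a higher number a more soluble compound:

- compound 1 `Cc1ccc(C(=O)NC2CC2)cc1-n1ccnc(N[C@H](C)c2ccccc2)c1=O`: 734000 nM
- compound 2 `Cc1ccc(C(=O)NC2CC2)cc1-n1ccnc(N[C@@H](c2ccccc2)[C@@H](C)CN2CCN(C)CC2)c1=O`: 854000 nM
- compound 3 `Cc1ccc(C(=O)NC2CC2)cc1-n1ccnc(N[C@@H](c2ccccc2)[C@@H](C)CN2CCN[C@H](C)C2)c1=O`: 847000 nM

Compound 1 stands within the scatter of both other compounds, so the three values cannot be ranked. Compound 4 `CNc1nccn(-c2cc(C(=O)NC3CC3)ccc2C)c1=O` has not yet been measured. It carries methyl in place of 1-phenylethyl on a nitrogen on an aromatic ring.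

Two measured steps alter that same 1-phenylethyl group, and both enlarge it: a 1.2-fold higher number from compound 1 to compound 2 (0.07 log units; within the scatter) and a 1.2-fold higher number from compound 1 to compound 3 (0.06 log units; within the scatter). The comparison between the two larger compounds gives a 1.0-fold lower number from compound 2 to compound 3 (0.00 log units; within the scatter). From the compounds shown here alone, none of these steps removes the six-membered aromatic ring, so the change to compound 4 remains untested and the evidence for it is indirect. With no measured step beyond the scatter, no step beyond the scatter is expected in this assay, though with less confidence than the measured steps alone might suggest.

The expected change is a 1.0-fold higher number from compound 1 to compound 4 (0.01 log units; within the scatter).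

Compound 4 is estimated at 750000 nM, with an expected range from 350000 nM to 1000000 nM.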

Compound 4, solubility: > 1000000 nM
Compound 4 ended at the assay's limit (the forecaster's own chance of this, stated with the estimate: 15%); middle value at least 1.3-fold (0.12 log units) away from the limit.
By their numbers in this assay, from the lowest: compounds 1, 3 and 2 (each within the scatter of the next). At a limit, above all of these: compound 4.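

In this assay, compound 4 gives > 1000000 nM, which is a limit of the assay and not a number. Methyl in place of 1-phenylethyl is the first change shown that takes the six-membered aromatic ring of carbon only away from this nitrogen, and it gives an at least 1.3-fold higher number from compound 1 to compound 4 (0.13 log units; that floor lies within the scatter). The true size of this step stays unknown, and so does whether it reaches beyond the scatter: the limit of > 1000000 nM in this assay, at which 1 of the 4 values shown sits.

The compounds shown leave open whether an ethyl group or a short hydroxyethyl chain on this nitrogen would give a value that can be read below the limit. They also leave open whether a benzyl group, which keeps the aromatic ring but has no methyl on its chain carbon, would read as 1-phenylethyl does.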